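The source may report more compounds than this note shows. Statements on the series, on what has been measured and on what is new or still open speak of the compounds shown alone.

Compounds measured in an assay on HEK293 cells for displacement of a labelled ligand from transient receptor potential cation channel subfamily V member 1 (Homo sapiens); on this read-out lower numbers stand for stronger inhibition and higher numbers for weaker inhibition:

compound 1, `O=C1COc2ccc(NC(=O)C3CCN(c4cccc(Cl)c4)CC3)cc2N1`, 97 nM
compound 2, `O=C1COc2ccc(NC(=O)C3CCN(c4ccccc4C(F)(F)F)CC3)cc2N1`, 68 nM

Compound 2 sits at the low end of the two numbers recorded so far, yet its separation from compound 1 is small: the step of a 1.4-fold lower number from compound 1 to compound 2 (0.15 log units; within the scatter) stays within the scatter, so the two compounds cannot be placed in order on this read-out.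

Compound 3, `Cc1c(Cl)cccc1N1CCC(C(=O)Nc2ccc3c(c2)NC(=O)CO3)CC1`, has not yet been measured. It differs from compound 2 only at the aryl group on the ring amine: 3-chloro-2-methylphenyl in place of 2-(trifluoromethyl)phenyl on an amine nitrogen in a ring.

Within the data shown here, only one measured step bears on this change, the one from compound 1 to compound 2, and that exchange of one aryl group for another at the same position gave a difference that stays within the scatter. On that basis a change of aryl group at this position is expected to leave the number in this assay essentially where compound 2 stands, with no step beyond the scatter in either direction.

For compound 3 the estimated step is a 1.2-fold higher number from compound 2 to compound 3 (0.07 log units; within the scatter). Compound 3 is therefore expected to give about 80 nM in this assay, with a likely range from 30 nM to 220 nM.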

Compound 3, inhibition constant: 100 nM
Compound 3: the middle estimate sits 1.3-fold (0.10 log units) below what was measured, within the range that was stated.
By their numbers in this assay, from the lowest: compounds 2, 1 and 3 (each within the scatter of the next).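

In this assay, 3-chloro-2-methylphenyl in place of 2-(trifluoromethyl)phenyl on the amine nitrogen in the ring gives a 1.5-fold higher number from compound 2 to compound 3 (0.17 log units; within the scatter), so a second exchange of aryl groups at this position also stays within the scatter. The result also adds a smaller change at the same position: methyl in place of hydrogen on an aromatic carbon, which turns 3-chlorophenyl into 3-chloro-2-methylphenyl, gives a 1.0-fold higher number from compound 1 to compound 3 (0.01 log units; within the scatter), so this added methyl has no effect that can be read in this assay. The three aryl groups therefore cannot be placed in order, and no supporting data accompany these numbers to explain this flat result.

Going by these compounds, all three compounds carry a substituted phenyl group of carbon only in the ring, so it remains open whether an unsubstituted phenyl, or a group of another kind such as a carboxylic acid or a chain ending in an amine, would move the number beyond the scatter. The shared core is the same throughout, so these compounds say nothing about how changes there would read.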